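The compounds below may be only part of what the source reports. "The series", "measured", "known", "first", "only" and "open" are said of these compounds alone.

In a physicochemical assay for solubility (a higher number here means a more soluble compound, a lower number a less soluble compound), compound 1 `O=C1OCCN1c1cc(C(F)(F)F)ccc1[C@H]1CCOc2cc(S(=O)(=O)Nc3nccs3)ccc21` gives 295000 nM while compound 2 `O=S(=O)(Nc1nccs1)c1ccc2c(c1)OCC[C@@H]2c1ccc(C(F)(F)F)cc1-n1ccnn1` gives 171000 nM and the two values sit within the usual scatter of each other. Compound 3 `O=S(=O)(Nc1nccs1)c1ccc2c(c1)OCC[C@@H]2c1ccc(C(F)(F)F)cc1-c1ccc(F)nc1` has not yet been measured. It differs from compound 2 by 6-fluoropyridin-3-yl in place of 1H-1,2,3-triazol-1-yl on an aromatic carbon, ortho to a large group and meta to a trifluoromethyl group 6-fluoropyridin-3-yl in place of 1H-1,2,3-triazol-1-yl on an aromatic carbon and the shared core stays the same. For the measured compounds named here, only one measured step bears on this change, a 1.7-fold lower number from compound 1 to compound 2 (0.24 log units; within the scatter) at the same aromatic carbon. That step involved a different pair of groups, so it sets no firm size here. A modest move to a lower number is still expected in this assay and the estimated step is a 2.4-fold lower number from compound 2 to compound 3 (0.39 log units; beyond the scatter) with wide uncertainty. For compound 3 the estimated value is 70000 nM with an expected range from 20000 nM to 200000 nM on this reading.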

Compound 3, solubility: 21000 nM
For compound 3 the middle estimate is 3.3-fold (0.52 log units) above the measured one; the range from low to high includes it.
By their numbers in this assay, from the lowest: compound 3; then compounds 2 and 1 (each within the scatter of the next).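

In this assay, this aromatic carbon, ortho to a large group and meta to a trifluoromethyl group, now shows a step beyond the scatter: 6-fluoropyridin-3-yl in place of 1H-1,2,3-triazol-1-yl gives an 8.1-fold lower number from compound 2 to compound 3 (0.91 log units; beyond the scatter) at this position, whereas the earlier change here stayed within the scatter. Measured against 2-oxo-1,3-oxazolidin-3-yl at the same carbon, the same group gives a 14-fold lower number from compound 1 to compound 3 (1.15 log units; beyond the scatter) and is rated large, so the group at this carbon can shift the number well beyond the scatter while the shared core stays the same. Nothing measured here accounts for this drop.

From the compounds shown here alone, whether the lower number goes with the six-membered aromatic ring itself or with its fluorine remains open. A plain phenyl or pyridin-3-yl at this carbon, or a pyridine ring carrying an amine or a carboxylic acid in place of the fluorine, would bear on that question.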